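Swapping morpholin-4-yl for a bicyclic carbon group

The compounds below may be only part of what the source reports. "The series", "measured", "known", "first", "only" and "open" are said of these compounds alone.

Measured compounds:
compound 1 `CO[C@H]1CC[C@H](NC(=O)c2n[nH]cc2NC(=O)c2ccc(F)cc2F)CC1`, with a value in this assay of 11000 nM
compound 2 `COc1cccc(OC)c1C(=O)Nc1c[nH]nc1C(=O)NN1CCOCC1`, reported only as the limit > 50000 nM
compound 3 `CO[C@H]1CC[C@H](NC(=O)c2n[nH]cc2NC(=O)C2CCOCC2)CC1`, reported only as the limit > 50000 nM

Within the data shown here, in an ADME assay on MRC5 cells (Homo sapiens) for inhibition, with a stated time of 72 h (a higher number here means that more compound is needed for the effect, a lower number that less compound is needed), compound 1 gives 11000 nM, the one actual number in the set. Compound 2 reaches only the limit of the assay, > 50000 nM, so no number is known for it. Compound 3 likewise sits at the limit, > 50000 nM. Compound 2 therefore stands at the limit of > 50000 nM in this assay, at which 2 of the 3 values shown sit.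

Compound 4 `COc1cccc(OC)c1C(=O)Nc1c[nH]nc1C(=O)NC1CC2CCC1C2` differs from compound 2 by a group of 7 heavy atoms (7 carbon; 2 five-membered non-aromatic rings of carbon only) in place of a group of 6 heavy atoms (4 carbon, 1 nitrogen, 1 oxygen; one six-membered non-aromatic ring with 2 hetero atoms), on an amide-type nitrogen. Among the measured compounds shown here, the only measured step, an at least 4.5-fold higher number from compound 1 to compound 3 (0.65 log units; beyond the scatter), concerns a group on a carbonyl carbon, not the amide-type nitrogen changed here, and so does not bear directly on this change. For the measured compounds named here, with no measured step at this position and compound 2 already at a limit, no step beyond the scatter is expected in either direction, and compound 4 is expected to stay at or close to the limit. Compound 4 is estimated at 40000 nM, within a range of 12000 nM to 50000 nM, which corresponds to an expected step of an at least 1.2-fold lower number from compound 2 to compound 4 (0.09 log units; that floor lies within the scatter).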

Compound 4, half-maximal effective concentration: > 50000 nM
Compound 4: only a limit was reported (the forecaster's own chance of this, stated with the estimate: 60%); middle value at least 1.2-fold (0.09 log units) from the limit.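

Compound 2 and compound 4 both sit at a limit rather than at an actual number, so no step can be read between them. Where they stand is this: the limit of > 50000 nM in this assay, at which 3 of the 4 values shown sit. The compounds shown leave open how much of compound 2 or compound 4 the effect would need, and so whether replacing morpholin-4-yl with the carbon-only group changes the result at all.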